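A few compounds are considered here, and "the series" means these few. Any claim that something is new, unique, unknown or untested is made for them only; others in the source may bear on it.

Of the compounds shown here, two have so far been tested in a functional assay on the whole organism (strain Zucker) for inhibition, with Rattus norvegicus as the target, with a stated time of 4 h, at a dose of 10 mg/kg by the oral route; a higher number here means more inhibition at the dose given (going by the name of the read-out), a lower number less inhibition. Compound 1 `O=C(NN1CCOCC1)C1=NN(c2ccc(Cl)cc2Cl)C(c2ccc(Br)cc2)C1` gives 24.2% in this assay. Compound 2 `Clc1ccc(N2N=C(CNN3CCOCC3)CC2c2ccco2)c(Cl)c1` gives 15.1% in this assay. Compound 2 thus stands at one end of the two numbers shown, yet its gap to compound 1 lies within the usual scatter of repeated measurements, so the two compounds cannot be told apart on these figures.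

Compound 3 `Clc1ccc(N2N=C(CNN3CCOCC3)CC2c2ccc(Cl)s2)c(Cl)c1` has not yet been measured. It differs from compound 2 in a single place: 5-chlorothiophen-2-yl in place of furan-2-yl on a saturated ring carbon. Among the compounds with values here, no two measured compounds differ in only one place, so there is no measured step of this kind to lean on, and the change swaps one five-membered aromatic ring with one hetero atom for another of the same description.

The step expected from compound 2 to compound 3 is a number 2.9 percentage points higher from compound 2 to compound 3 (within the scatter), which is no change beyond the scatter. Compound 3 is therefore expected to give about 18%, somewhere between 4% and 34%.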

Compound 3, a percentage reported as inhibition, in the whole organism at one dose (the size of the read-out at that dose, not a potency): 16.7%
Beside the measured number, compound 3's estimate is 1.3 percentage points above it, and the stated range covers the measured number.
By their numbers in this assay, from the lowest: compounds 2, 3 and 1 (each within the scatter of the next).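

Within the data shown here, the one step now measured is a number 1.6 percentage points higher from compound 2 to compound 3 (within the scatter) for 5-chlorothiophen-2-yl in place of furan-2-yl on a saturated ring carbon. In this assay, this position therefore accepts a larger five-membered aromatic ring, with sulfur for oxygen and an added chlorine, without a difference that can be told from the scatter. Nothing measured here explains this result or separates what the sulfur and the chlorine each contribute.

Both groups tested in this pair are five-membered aromatic rings with one hetero atom, so the step says nothing about a non-aromatic group such as cyclohexyl or about a basic group such as an aminomethyl chain at this carbon. Plain thiophen-2-yl, without the chlorine, would be needed to separate the two parts of this change.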